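Two spirocyclic amide variants against an intracellular cholesterol transporter

The source may report more compounds than this note shows. Statements on the series, on what has been measured and on what is new or still open speak of the compounds shown alone.

Measured compounds:
compound 1, `CC(C)CNC(=O)CN1CN(c2ccccc2)C2(CCN(C(=O)c3ccc(C(C)(C)C)cc3)CC2)C1=O`, 4400 nM
compound 2, `Cn1c(N(Cc2ccc(OCCCC(=O)O)cc2)[C@H]2CC[C@H](C(C)(C)C)CC2)nc2cc(OC3CCCC3)ccc21`, 7400 nM

Going by the values given here, in an assay on HEK293 cells for displacement of a labelled ligand from NPC1-like intracellular cholesterol transporter 1 (Homo sapiens) (on this read-out lower numbers stand for stronger inhibition and higher numbers for weaker inhibition), compound 1 gives 4400 nM, the lowest of the two numbers measured so far. Compound 2 (`Cn1c(N(Cc2ccc(OCCCC(=O)O)cc2)[C@H]2CC[C@H](C(C)(C)C)CC2)nc2cc(OC3CCCC3)ccc21`) is built on a different scaffold and in this assay compound 2 gives 7400 nM; the gap between the two lies within the scatter, so no order between them can be read from these figures.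

Compound 3 (`CC(C)(C)c1ccc(C(=O)N2CCC3(CC2)C(=O)N(CC(=O)N2CCCCC2)CN3c2ccccc2)cc1`) shares the core of compound 1 and differs from it in one place: piperidin-1-yl in place of isobutylamino on a carbonyl carbon. The secondary amide of compound 1 thus becomes a tertiary amide in compound 3, the hydrogen-bond donor on the amide nitrogen being lost. Among the compounds with values here, no measured pair shows what such a change does on this scaffold, so the direction of the step cannot be anchored on data.

The step of a 1.1-fold higher number from compound 1 to compound 3 (0.06 log units; within the scatter) is therefore expected to be small, not clearly beyond the scatter in either direction. For compound 3 the estimated value is 5000 nM, with a range from 1500 nM to 16000 nM.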

Compound 3, half-maximal inhibitory concentration: 2500 nM
Beside the measured number, compound 3's estimate is 2.0-fold (0.30 log units) above it; low and high end bracket the measured number.
By their numbers in this assay, from the lowest: compounds 3, 1 and 2 (each within the scatter of the next, the first and the last beyond it).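

In this assay, going by these compounds alone, the first pair differing in one place gives a 1.8-fold lower number from compound 1 to compound 3 (0.25 log units; within the scatter), so piperidin-1-yl in place of isobutylamino on a carbonyl carbon produces no step that can be told from the scatter. This position therefore accepts a six-membered non-aromatic ring in place of an open branched group, and the loss of the amide hydrogen does not carry the number beyond the scatter, though a single pair cannot show whether that holds for other groups here. No measurement at hand bears on why the two numbers stay so close.

What the compounds shown leave open is whether a morpholin-4-yl ring, with an oxygen in the ring, or a small dimethylamino group on the same carbonyl carbon would also stay within the scatter of compound 1. From the compounds shown here alone, it also remains open whether a free carboxylic acid or a basic amine at the end of a longer chain at this position would move the number clearly in either direction.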